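Solubility notes: thiazolylmethylamine variant of compound 1

This account rests on a few compounds, and the source may have more. Where it says the series, first, only, none or still open, it means among the compounds named here.

Among the compounds with values here, in a physicochemical assay for solubility, read by HPLC, using the shake flask method, measured as kinetic solubility, with a stated time of 2 h, at pH 7.4 (a higher number here means a more soluble compound, a lower number a less soluble compound), compound 1 `Cc1cc(NCc2ccncc2)n2nc(C)c(-c3ccccc3)c2n1` gives 134000 nM, the highest of the two numbers so far. Its nearest neighbour is compound 2 `Cc1cc(OCc2ccccn2)n2nc(C)c(-c3ccccc3)c2n1`, which in this assay gives 25600 nM; the step of a 5.2-fold lower number from compound 1 to compound 2 (0.72 log units; beyond the scatter) exchanges the whole side chain, (pyridin-2-yl)methoxy in place of ((pyridin-4-yl)methyl)amino on an aromatic carbon, and so changes linker and ring together. Compound 3 `Cc1cc(NCc2nccs2)n2nc(C)c(-c3ccccc3)c2n1` keeps the amino linker of compound 1 and differs only by 1,3-thiazol-2-yl in place of pyridin-4-yl on a saturated chain carbon bound to a nitrogen on an aromatic ring. Within the data shown here, no measured step isolates a ring swap on an unchanged linker, so the one step known is only a loose guide; it shows that side-chain changes of this size move the number modestly. A step no larger than that, and more likely within the scatter, is expected from compound 1 to compound 3 as a 1.5-fold lower number from compound 1 to compound 3 (0.17 log units; within the scatter). Compound 3 is accordingly estimated at 90000 nM, with a range of 30000 nM to 250000 nM.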

Compound 3, solubility: 108000 nM
Beside the measured number, compound 3's estimate is 1.2-fold (0.08 log units) below it; the range from low to high includes it.
By their numbers in this assay, from the lowest: compound 2; then compounds 3 and 1 (each within the scatter of the next).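

On a saturated chain carbon bound to a nitrogen on an aromatic ring, the amino linker held constant, 1,3-thiazol-2-yl in place of pyridin-4-yl gives in this assay a 1.2-fold lower number from compound 1 to compound 3 (0.09 log units; within the scatter) and so places compound 1 and compound 3 level within the scatter. The step from the other side chain, a 4.2-fold higher number from compound 2 to compound 3 (0.63 log units; beyond the scatter) with ((1,3-thiazol-2-yl)methyl)amino in place of (pyridin-2-yl)methoxy on an aromatic carbon, is beyond the scatter and close in size to the earlier side-chain step read in reverse. No supporting data bear on why either step has its size.

The separate shares of linker and ring in the step from compound 2 remain unresolved. Also open, as far as these compounds go, is how a carboxylic acid, a tertiary amine or a longer chain in this side chain would read in this assay on the same core.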